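Series notes: aromatic methyl step toward compound 4

This account rests on a few compounds, and the source may have more. Where it says the series, first, only, none or still open, it means among the compounds named here.

Measured so far, all in an assay on liver for inhibition of sterol O-acyltransferase 1 (Rattus norvegicus), using microsomes; a higher number here means a weaker inhibitor, a lower number a stronger inhibitor:
compound 1 `CC(C)(C)c1cccc(C(C)(C)C)c1OC(=O)NS(=O)(=O)Nc1ccccc1`: 19000 nM
compound 2 `CC(C)(C)c1cccc(C(C)(C)C)c1OC(=O)NS(=O)(=O)NC(c1ccccc1)c1ccccc1`: 11400 nM
compound 3 `Cc1cc(C(C)(C)C)c(OC(=O)NS(=O)(=O)Nc2ccccc2)c(C(C)(C)C)c1`: 23400 nM

Compound 1 and compound 3 differ in one place, (methyl in place of hydrogen on an aromatic carbon), and that gives a 1.2-fold higher number from compound 1 to compound 3 (0.09 log units; within the scatter). Compound 2 differs from compound 1 in the core; the difference between the two cores is not broken down here. Compound 4 `Cc1cc(C(C)(C)C)c(OC(=O)NS(=O)(=O)NC(c2ccccc2)c2ccccc2)c(C(C)(C)C)c1` remains unmeasured in this assay. It stands to compound 2 exactly as compound 3 stands to compound 1, (methyl in place of hydrogen on an aromatic carbon), the same change at the same place. Because the step of a 1.2-fold higher number from compound 1 to compound 3 (0.09 log units; within the scatter) lies within the scatter, the step from compound 2 to compound 4 is expected to be of similar size, a 1.2-fold higher number from compound 2 to compound 4 (0.07 log units; within the scatter). On that basis compound 4 is expected near 13500 nM in this assay. The range for compound 4 is estimated from 7000 nM to 27000 nM.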

Compound 4, half-maximal inhibitory concentration: 11500 nM
Estimate against measurement, compound 4: 1.2-fold (0.07 log units) above; measured number inside the range.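

In this assay, methyl in place of hydrogen on an aromatic carbon gives a 1.0-fold higher number from compound 2 to compound 4 (0.00 log units; within the scatter). Set beside the earlier step on the core of compound 1, the result on the core of compound 2 shows no difference between the two cores: the same change on two cores in this assay, a 1.2-fold higher number (0.09 log units; within the scatter) from compound 1 to compound 3 and a 1.0-fold higher number (0.00 log units; within the scatter) from compound 2 to compound 4, 1.2-fold (0.09 log units) apart, within the scatter of two such steps. For the compounds shown here, both steps lie within the scatter, so this agreement shows only that the change leaves no readable mark on these two cores, not that it would do the same on any other core.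

The compounds shown leave open whether a different group at this carbon, such as an amine, a carboxylic acid or a longer chain, would give a step beyond the scatter. They also leave open how methyl behaves at any other ring carbon.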